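A few compounds are considered here, and "the series" means these few. Any claim that something is new, unique, unknown or untested is made for them only; others in the source may bear on it.

Measured so far:
- compound 1 `CN1C[C@H](C(=O)Nc2ccccc2)[C@@H](c2ccc(/C=C/C(=O)Nc3ccccc3N)cc2)C1`: 67 mL/min/kg
- compound 2 `Cc1cc(NC(=O)[C@H]2CN(C)C[C@@H]2c2ccc(/C=C/C(=O)Nc3ccccc3N)cc2)ccc1F`: 62 mL/min/kg

Both values come from an in vitro ADME assay on microsomes from liver (Mus musculus) for pharmacokinetics, read by LC-MS, with a stated time of 10 min, tested at 1 uM; on this read-out lower numbers stand for slow clearance and higher numbers for fast clearance. Compound 2 stands level with compound 1 on these numbers, since the gap between them lies within the usual scatter of repeated measurements. The next compound to be tested is compound 3 `CN1C[C@H](C(=O)Nc2ccccn2)[C@@H](c2ccc(/C=C/C(=O)Nc3ccccc3N)cc2)C1`, which carries pyridin-2-yl in place of 4-fluoro-3-methylphenyl on an amide-type nitrogen.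

Within the data shown here, only one measured step bears on this change. It is a 1.1-fold lower number from compound 1 to compound 2 (0.03 log units; within the scatter), which put 4-fluoro-3-methylphenyl in place of phenyl at the same amide-type nitrogen and stayed within the scatter. Clearance in this assay therefore did not respond to that exchange. However, no measured compound yet has a ring with a hetero atom at this place, so the data cannot show what pyridin-2-yl will do, and the expectation stays wide. No shift beyond the scatter is expected, and the estimated change is a 1.1-fold lower number from compound 2 to compound 3 (0.05 log units; within the scatter). For compound 3 the expected clearance is 55 mL/min/kg, with an estimated range of 30 mL/min/kg to 90 mL/min/kg.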

Compound 3, clearance: 40 mL/min/kg
Estimate against measurement, compound 3: 1.4-fold (0.14 log units) above; low and high end bracket the measured number.
By their numbers in this assay, from the lowest: compounds 3, 2 and 1 (each within the scatter of the next).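

Compound 3 is the only compound shown whose ring on the amide-type nitrogen holds a hetero atom, and in this assay the exchange of 4-fluoro-3-methylphenyl for pyridin-2-yl gives a step (a 1.6-fold lower number from compound 2 to compound 3 (0.19 log units; within the scatter)) that stays within the scatter, as does the exchange of phenyl for pyridin-2-yl (a 1.7-fold lower number from compound 1 to compound 3 (0.22 log units; within the scatter)). Among these compounds, this position therefore took a ring with a hetero atom and a hydrogen-bond acceptor, in place of either all-carbon ring, and no step left the scatter, so the three compounds stand level on these numbers, a reading that the earlier pair, with only all-carbon rings, could not give. Nothing shown here gives a measured reason for these numbers.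

What the compounds leave open is whether any group on this amide-type nitrogen can move clearance beyond the scatter, and whether the place of the ring nitrogen counts, as pyridin-3-yl or pyridin-4-yl would show. They also leave open what a group other than an aromatic ring would do here, such as a piperidin-4-yl ring or a plain methyl, and what a carboxylic acid on the phenyl ring would do.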